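Amide in Place of Ether on a Fused Lactam Core

The source may hold more compounds than are shown below. What is called first, only, known or untested is meant among the compounds shown, and "the series" means these compounds.

Compound 2 `Cc1noc(C)c1COC1CC(=O)Nc2c1c(C)nn2-c1ncnc2nc[nH]c12` stands at the top of the two numbers gathered so far: in a functional assay on HEK293 cells for agonist activity at G-protein coupled receptor 39 (Homo sapiens), read by scintillation proximity assay and inositol phosphate accumulation, with a stated time of 75 min, in the presence of a further agent that is not named here (on this read-out higher numbers stand for an effect only at larger amounts of compound and lower numbers for an effect already at smaller amounts), compound 2 gives 5 nM, whereas compound 1 `Cc1nn(-c2ncnc3nc[nH]c23)c2c1C(OC1CCCC1)CC(=O)N2` gives 2 nM in this assay. Among the compounds with values here, the only measured step is a 2.5-fold higher number from compound 1 to compound 2 (0.40 log units; beyond the scatter), a change at the oxygen on a saturated carbon. Compound 3 `Cc1nn(-c2ncnc3nc[nH]c23)c2c1C(NC(=O)c1ccccc1)CC(=O)N2` differs from compound 2 at that same carbon: benzamido in place of (3,5-dimethyl-1,2-oxazol-4-yl)methoxy on a saturated ring carbon. Within the data shown here, no measured step swaps an ether for an amide there, so the step from compound 1 to compound 2 bears on it only by showing that the position tolerates a different group with a modest shift. The step is expected to be a 2.0-fold higher number from compound 2 to compound 3 (0.30 log units; within the scatter), most likely a small rise or nothing beyond the scatter. The estimate for compound 3 in this assay is 10 nM, with a range from 2 nM to 50 nM.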

Compound 3, half-maximal effective concentration: 3 nM
Beside the measured number, compound 3's estimate is 3.3-fold (0.52 log units) above it; the measured number falls inside the stated range.
By their numbers in this assay, from the lowest: compounds 1, 3 and 2 (each within the scatter of the next, the first and the last beyond it).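

The amide linkage, carried by neither compound 1 nor compound 2, is accepted on the saturated ring carbon: the change to benzamido gives a 1.7-fold lower number from compound 2 to compound 3 (0.22 log units; within the scatter), and the comparison with the cyclopentyloxy group gives a 1.5-fold higher number from compound 1 to compound 3 (0.18 log units; within the scatter). The position therefore takes benzamido, with its hydrogen-bond donor and six-membered aromatic ring of carbon only, without a shift beyond the scatter from either ether. Nothing available explains these small steps.

Compound 3 alone carries the amide hydrogen, so whether that hydrogen contributes to its activity remains unresolved. On these data alone, it also remains open whether a plain amine on the saturated ring carbon, or a carboxylic acid on the aromatic ring of the benzamido group, would be tolerated as well.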